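The source may hold more compounds than are shown below. What is called first, only, known or untested is meant among the compounds shown, and "the series" means these compounds.

Measured so far in a functional assay on A-375 cells (Homo sapiens) for antiproliferative activity, read by CCK-8 assay, with a stated time of 72 h, tested at 2 uM; a higher number here means a stronger effect of the compound at the concentration tested, a lower number a weaker effect:
compound 1, `Nc1ccccc1NC(=O)c1ccc(CSC(=S)N2CCN(Cc3ccncc3)CC2)cc1`: compound 1 gives 33.1%.
compound 2, `Nc1ccccc1NC(=O)c1ccc(CSC(=S)N2CCN(c3ccccc3F)CC2)cc1`: compound 2 gives 18.7%.

Compound 2 stands lowest of the two numbers; its nearest neighbour is compound 1. For the measured compounds named here, the only measured step, a number 14.4 percentage points lower from compound 1 to compound 2 (beyond the scatter), runs in the opposite sense to the change now considered. Compound 3, `Nc1ccccc1NC(=O)c1ccc(CSC(=S)N2CCN(Cc3cccnc3)CC2)cc1`, differs from compound 2 by (pyridin-3-yl)methyl in place of 2-fluorophenyl on an amine nitrogen in a ring. The entering group is close to the (pyridin-4-yl)methyl of compound 1, so a step of about that size in this assay, now upward, is expected. The expected step from compound 2 is a number 12.3 percentage points higher from compound 2 to compound 3 (beyond the scatter). Compound 3 is estimated at 31%, range 18% to 44%.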

Compound 3, a percentage reported as inhibition, at one concentration (the size of the read-out at that concentration, not a potency): 31.5%
Compound 3: middle estimate off by 0.5 percentage points, on the low side; the measured number falls inside the stated range.
By their numbers in this assay, from the lowest: compound 2; then compounds 3 and 1 (each within the scatter of the next).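

In this assay, pyridin-3-yl in place of pyridin-4-yl gives a number 1.6 percentage points lower from compound 1 to compound 3 (within the scatter), so these two attachment forms of the pyridine ring are not told apart at this position. The (pyridin-3-yl)methyl group also gives a number 12.8 percentage points higher from compound 2 to compound 3 (beyond the scatter), which shows that the gap to compound 2 is not confined to the pyridin-4-yl form. No evidence accounts for either step.

From the compounds shown here alone, the step from compound 2 changes the ring and adds a saturated carbon together, so their separate contributions remain open. A benzyl group at this nitrogen would separate them.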